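The compounds below may be only part of what the source reports. "The series", "measured", "known", "first", "only" and "open" are said of these compounds alone.

Measured compounds:
- Compound 1, `COC(=O)c1cc(-n2cc(-c3cc(OC)cc(OC)c3)nn2)ccc1O`: 3%
- Compound 2, `COc1cc(OC)cc(-c2cn(-c3ccc(O)c(C(=O)O)c3)nn2)c1`: 9%

Of the compounds shown here, two have been measured in a functional assay on CCRF-CEM cells (Homo sapiens) for inhibition, read by MTT assay, with a stated time of 2 days, tested at 10 uM; a lower number here means less inhibition, a higher number more inhibition at the concentration tested (going by the name of the read-out). Compound 1, `COC(=O)c1cc(-n2cc(-c3cc(OC)cc(OC)c3)nn2)ccc1O`, gives 3%, and compound 2, `COc1cc(OC)cc(-c2cn(-c3ccc(O)c(C(=O)O)c3)nn2)c1`, gives 9%. For the measured compounds named here, the one step between them, a number 6 percentage points higher from compound 1 to compound 2 (within the scatter), is the only measured change at the oxygen next to the carbonyl group, and it lies within the scatter. Compound 2 therefore stands at the higher of the two numbers, but the gap to compound 1 is not one that separates the two compounds.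

Compound 3, `COc1cc(OC)cc(-c2cn(-c3ccc(O)c(C(=O)OCCCc4ccccc4)c3)nn2)c1`, has not yet been measured. It differs from compound 2 in one place: 3-phenylpropyl in place of hydrogen on an oxygen next to a carbonyl group. The measured step from methyl to hydrogen at this oxygen bears on this change, and it was within the scatter, so nothing in the measured data points to a step beyond the scatter in this assay for a larger group at the same oxygen. The step from compound 2 to compound 3 is therefore expected to be small, a number 3 percentage points higher from compound 2 to compound 3 (within the scatter). Compound 3 is accordingly expected to give about 12% in this assay, with a range from 0% to 35%.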

Compound 3, a percentage reported as inhibition, at one concentration (the size of the read-out at that concentration, not a potency): 8%
For compound 3 the middle estimate is 4 percentage points above the measured one; the range from low to high includes it.
By their numbers in this assay, from the lowest: compounds 1, 3 and 2 (each within the scatter of the next).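

In this assay, the oxygen next to a carbonyl group now carries three different groups across the series: methyl in compound 1, hydrogen in compound 2 and 3-phenylpropyl in compound 3. Setting 3-phenylpropyl in place of hydrogen on that oxygen gives a number 1 percentage points lower from compound 2 to compound 3 (within the scatter) and, read from the methyl side, phenethyl in place of hydrogen on the saturated chain carbon bound to that oxygen gives a number 5 percentage points higher from compound 1 to compound 3 (within the scatter) so adding 9 heavy atoms and a six-membered aromatic ring of carbon only separates compound 3 from neither neighbour, something the earlier exchange of methyl and hydrogen could not show for a group of this size. Nothing available explains this outcome.

The compounds shown leave open whether a different kind of group on this oxygen, such as a chain ending in an amine or in a carboxylic acid, would move the number beyond the scatter. They also leave open how the shared core responds to change elsewhere, since all three compounds keep it unaltered.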